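The source may report more compounds than this note shows. Statements on the series, on what has been measured and on what is new or still open speak of the compounds shown alone.

In a functional assay on A549 cells (Homo sapiens) for inhibition, read by MTT assay, with a stated time of 24 h (on this read-out higher numbers stand for weaker inhibition of growth and lower numbers for stronger inhibition of growth), compound 1 `COc1ccccc1C(=O)n1c(-c2cn(C)c3ccccc23)nc2ccccc21` gives 12300 nM and compound 2 `COc1ccc(C(=O)n2c(-c3cn(C)c4ccccc34)nc3ccccc32)cc1` gives 10400 nM while compound 3 `COc1ccc2c(c1)c(-c1nc3ccccc3n1C(=O)c1ccccc1OC)cn2C` gives 11900 nM and so lies within the scatter of both. Compound 4 `COc1ccc2c(c1)c(-c1nc3ccccc3n1C(=O)c1ccc(OC)c(OC)c1)cn2C` differs from compound 3 on a carbonyl carbon: 3,4-dimethoxyphenyl in place of 2-methoxyphenyl on a carbonyl carbon is the whole change. Within the data shown here, two measured steps bear on it: a 1.2-fold lower number from compound 1 to compound 2 (0.07 log units; within the scatter) for a swap on that same kind of carbon and a 1.0-fold lower number from compound 1 to compound 3 (0.01 log units; within the scatter) for methoxy in place of hydrogen on an aromatic carbon, both within the scatter. Among the measured compounds shown here, no step beyond the scatter is therefore expected in this assay although no measured compound carries 3,4-dimethoxyphenyl. The expected step is a 1.2-fold lower number from compound 3 to compound 4 (0.08 log units; within the scatter) and stays within the scatter. Compound 4 is estimated at 10000 nM with an expected range of 5000 nM to 18000 nM on present evidence.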

Compound 4, concentration for 50% growth inhibition: 2700 nM
Compound 4: the middle estimate sits 3.7-fold (0.57 log units) above what was measured; the measured number lies below the stated range.
By their numbers in this assay, from the lowest: compound 4; then compounds 2, 3 and 1 (each within the scatter of the next).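

On the carbonyl carbon, 3,4-dimethoxyphenyl in place of 2-methoxyphenyl gives a 4.4-fold lower number from compound 3 to compound 4 (0.64 log units; beyond the scatter) in this assay. Among these compounds, this is the only step beyond the scatter, so the group on this carbon can move the read-out, which the swap to 4-methoxyphenyl did not show. Nothing measured here accounts for the step.

Going by these compounds, it remains open whether the step holds on the core of compound 1, which lacks the core methoxy. Also open, on these data alone, is whether an ethoxy group or a dimethylamino group on that ring would keep the lower number.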